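Cyanobenzyl analogue in the arylpiperazine urea series

A few compounds are considered here, and "the series" means these few. Any claim that something is new, unique, unknown or untested is made for them only; others in the source may bear on it.

Two members of the series have been measured. Compound 1 `COc1ccccc1N1CCN(CCCNC(=O)NN(Cc2cccc(F)c2)c2ccc(F)cc2)CC1` gives 3.8 nM in an assay on CHO cells for displacement of a labelled ligand from D(4) dopamine receptor (Homo sapiens), read by radioligand binding; a higher number here means a weaker inhibitor, a lower number a stronger inhibitor. Compound 2 `COc1cccc(CN(NC(=O)NCCCN2CCN(c3ccccc3OC)CC2)c2ccc(F)cc2)c1` gives 5.9 nM in this assay; of the two numbers compound 2 has the higher one, but its separation from compound 1 is a 1.6-fold higher number from compound 1 to compound 2 (0.19 log units; within the scatter), within the scatter. Compound 3 `COc1ccccc1N1CCN(CCCNC(=O)NN(Cc2ccc(C#N)cc2)c2ccc(F)cc2)CC1` is not yet measured. Relative to compound 2 the change is 4-cyanophenyl in place of 3-methoxyphenyl on a saturated chain carbon bound to a nitrogen on an aromatic ring. Going by the values given here, the only step that bears on it, a substituent swap on the same benzyl ring, came out as a 1.6-fold higher number from compound 1 to compound 2 (0.19 log units; within the scatter), so such a change has so far left the number essentially unmoved. Compound 3 is therefore expected to stay in the same range, with a step estimated at a 1.1-fold lower number from compound 2 to compound 3 (0.03 log units; within the scatter), no direction claimed beyond the scatter. The estimate for compound 3 in this assay is 5.5 nM, with a range from 1.8 nM to 18 nM.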

Compound 3, inhibition constant: 15 nM
For compound 3 the middle estimate is 2.7-fold (0.44 log units) below the measured one; low and high end bracket the measured number.
By their numbers in this assay, from the lowest: compounds 1 and 2 (each within the scatter of the next); then compound 3.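

Unlike the swap of methoxy for fluoro, which stayed within the scatter, the change at this place on a saturated chain carbon bound to a nitrogen on an aromatic ring does move the number in this assay. 4-Cyanophenyl in place of 3-methoxyphenyl gives a 2.5-fold higher number from compound 2 to compound 3 (0.41 log units; beyond the scatter), and 4-cyanophenyl in place of 3-fluorophenyl gives a 3.9-fold higher number from compound 1 to compound 3 (0.60 log units; beyond the scatter), so both steps point towards a weaker inhibitor and both remain modest. No measurement at hand accounts for these steps.

The compounds shown leave open whether the higher number goes with the nitrile or with the move from a 3-substituted to a 4-substituted phenyl, as the two change together here. A 3-cyanophenyl or a 4-methoxyphenyl group at the same place would separate the two.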